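Sulfonamide nitrogen substituent: benzyl to methyl

The compounds below may be only part of what the source reports. "The series", "measured", "known", "first", "only" and "open" are said of these compounds alone.

Compound 1 `CCCCc1ccc(CNCc2ccccc2)c(=O)n1Cc1ccc(-c2ccccc2-c2nn[nH]n2)cc1` gives 1 nM in a functional assay (aorta) for antagonist activity, with Oryctolagus cuniculus as the target; a higher number here means a weaker inhibitor, a lower number a stronger inhibitor. Compound 2 `CCCCNC(=O)NCc1ccc(CCCC)n(Cc2ccc(-c3ccccc3-c3nn[nH]n3)cc2)c1=O` gives 10 nM in this assay, and compound 3 `CCCCc1ccc(CN(Cc2ccccc2)S(=O)(=O)c2ccc(C)cc2)c(=O)n1Cc1ccc(-c2ccccc2-c2nn[nH]n2)cc1` gives 60 nM. Compound 3 therefore stands highest of the three numbers; both other compounds are beyond the scatter below it.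

The step to compound 4 `CCCCc1ccc(CN(C)S(=O)(=O)c2ccc(C)cc2)c(=O)n1Cc1ccc(-c2ccccc2-c2nn[nH]n2)cc1` is hydrogen in place of phenyl on a saturated chain carbon bound to a sulfonamide nitrogen. Within the data shown here, no measured step touches the benzyl group on the sulfonamide nitrogen directly. Among the measured compounds shown here, two steps bear on it indirectly: a 60-fold higher number from compound 1 to compound 3 (1.78 log units; beyond the scatter) shows how strongly the sulfonyl group on the amine nitrogen moved the number, and a 10-fold higher number from compound 1 to compound 2 (1.00 log units; beyond the scatter) shows that exchanging the benzyl on the amine nitrogen for another group was costly in compound 1. Shrinking benzyl to methyl on the sulfonamide nitrogen is a change of a different kind, so the direction is uncertain; a step of modest size is expected, more likely upward than downward.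

Compound 4 is expected to give 100 nM in this assay, within 30 nM to 400 nM, a step of a 1.7-fold higher number from compound 3 to compound 4 (0.22 log units; within the scatter).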

Compound 4, half-maximal inhibitory concentration: 8 nM
The estimate for compound 4 lay 13-fold (1.10 log units) above the measured number, outside the stated range (below it).
By their numbers in this assay, from the lowest: compound 1; then compounds 4 and 2 (each within the scatter of the next); then compound 3.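

In this assay, hydrogen in place of phenyl on a saturated chain carbon bound to a sulfonamide nitrogen gives a 7.5-fold lower number from compound 3 to compound 4 (0.88 log units; beyond the scatter), so this substituent clearly moves the number, and methyl gives the lower number of the two groups tested here. Methyl((4-methylphenyl)sulfonyl)amino in place of benzylamino still gives an 8.0-fold higher number from compound 1 to compound 4 (0.90 log units; beyond the scatter), so the methyl sulfonamide does not match the benzylamino group, while in place of (butylcarbamoyl)amino it gives a 1.3-fold lower number from compound 2 to compound 4 (0.10 log units; within the scatter), which does not separate those two compounds. Nothing available here explains the benzyl-to-methyl step.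

On these data alone, it remains open whether hydrogen, ethyl or a longer chain such as n-butyl on the sulfonamide nitrogen would continue this trend. As far as these compounds go, the effect of replacing the 4-methylphenyl on the sulfonyl group, for example with methyl, also remains open.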